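The compounds below may be only part of what the source reports. "The series", "measured", "known", "first", "only" and "open" are said of these compounds alone.

Of the compounds shown here, three share a core and have been measured in an assay on cell membranes for displacement of a labelled ligand from Neuronal acetylcholine receptor; alpha4/beta2 (Rattus norvegicus); on this read-out lower numbers stand for stronger inhibition and higher numbers for weaker inhibition. Compound 1 `Clc1ccc(Nc2ccc(N3CC4CC(C3)N4)nn2)cc1Cl` gives 516 nM. Compound 2 `Cc1ccc(Nc2cncc(N3CC4CC(C3)N4)c2)cc1` gives 0.148 nM. Compound 3 `c1ccc(Nc2ccc(N3CC4CC(C3)N4)nn2)cc1` gives 441 nM, the second highest of the three numbers; its gap to compound 1 lies within the usual scatter, while compound 2 sits far lower, well beyond it. Compound 4 `CN(c1ccccc1)c1ccc(N2CC3CC(C2)N3)nn1` has not yet been measured. It differs from compound 3 by methyl in place of hydrogen on a nitrogen on an aromatic ring. Among the measured compounds shown here, no measured pair shows this change, so the size of its effect is open. The step of a 1.7-fold higher number from compound 3 to compound 4 (0.23 log units; within the scatter) is expected to be small, toward a higher number, and possibly not beyond the scatter. Compound 4 is therefore estimated at 750 nM, with a range from 200 nM to 2800 nM.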

Compound 4, inhibition constant: 1430 nM
Beside the measured number, compound 4's estimate is 1.9-fold (0.28 log units) below it; the measured number falls inside the stated range.
By their numbers in this assay, from the lowest: compound 2; then compounds 3 and 1 (each within the scatter of the next); then compound 4.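

In this assay swapping the hydrogen on this nitrogen for methyl gives a 3.2-fold higher number from compound 3 to compound 4 (0.51 log units; beyond the scatter) and thus weaker inhibition. This is the only single change that can be read among these compounds, and it shows that on this core the nitrogen on the aromatic ring does not take one added methyl without a measurable loss. Nothing available here explains the loss. As far as these compounds go, whether an ethyl or an acetyl group on this nitrogen would lose more or less remains open. So does whether methyl has the same effect on the core of compound 2.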